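The compounds below may be only part of what the source reports. "The series", "measured", "known", "first", "only" and "open" are said of these compounds alone.

Measured so far in a functional assay on HT-29 cells (Homo sapiens) for antiproliferative activity, read by MTT assay, with a stated time of 48 h (on this read-out lower numbers stand for stronger inhibition of growth and higher numbers for weaker inhibition of growth), for two compounds:
- compound 1 `COc1cc(C2CC(c3ccccc3)=NN2C(=O)OCc2ccccc2)cc(OC)c1OC` gives > 10000 nM
- compound 2 `CCOC(=O)N1N=C(c2cccc(O)c2)CC1c1cc(OC)c(OC)c(OC)c1` gives 11600 nM

Going by the values given here, compound 2 at 11600 nM holds the only actual number in this assay so far. Compound 1 reports > 10000 nM as a limit of the assay and not a number.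

Compound 3 `COc1cc(C2CC(c3cccc(O)c3)=NN2C(=O)OCc2ccccc2)cc(OC)c1OC` has not yet been measured. The change phenyl in place of methyl on a saturated chain carbon bound to an oxygen next to a carbonyl group is phenyl in place of methyl on a saturated chain carbon bound to an oxygen next to a carbonyl group, so ethoxycarbonyl becomes benzyloxycarbonyl. Among the compounds with values here, no measured pair shows this change on its own, so its size cannot be read directly from the data. Compound 1 also carries benzyloxycarbonyl, and it gave only the limit noted earlier. On that basis, no shift beyond the usual scatter is expected in this assay in either direction, and compound 3 may also end at a limit. The estimated step of a 1.3-fold lower number from compound 2 to compound 3 (0.11 log units; within the scatter) stays within that scatter. For compound 3 the expected value is 9000 nM within an estimated range from 3000 nM to 30000 nM overall.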

Compound 3, concentration for 50% growth inhibition: > 10000 nM
Compound 3 was reported as a limit (the forecaster's own chance of this, stated with the estimate: 40%); middle value at least 1.1-fold (0.04 log units) from the limit.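

In this assay compound 3 gives > 10000 nM, which is a limit of the assay and not a number. Neither the step from compound 2 to compound 3 nor the step from compound 1 to compound 3 can be read, because the comparison ends at a limit: the limit of > 10000 nM in this assay, at which 2 of the 3 values shown sit.

The compounds shown leave open whether benzyloxycarbonyl in place of ethoxycarbonyl, or hydroxy in place of hydrogen on an aromatic carbon, changes growth inhibition at all.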